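Swapping sulfur for oxygen in the ring of compound 2

This account rests on a few compounds, and the source may have more. Where it says the series, first, only, none or still open, it means among the compounds named here.

Measured so far:
compound 1 `CC(C)(C)OC(=O)N(Cc1ccco1)C(=O)c1ccc(CN2C(=O)c3ccccc3C2=O)cc1`: 3450 nM
compound 2 `CC(C)(C)OC(=O)N(Cc1ccco1)C(=O)c1ccc(Cn2sc3ccccc3c2=O)cc1`: 68000 nM

Among the measured compounds shown here, in a functional assay on RAW264.7 cells (Mus musculus) for inhibition (on this read-out lower numbers stand for stronger inhibition and higher numbers for weaker inhibition), compound 2 gives the highest number of the two, and the only step known is a 20-fold higher number from compound 1 to compound 2 (1.29 log units; beyond the scatter), which replaced the whole ring pair on the saturated chain carbon. Compound 3 `CC(C)(C)OC(=O)N(Cc1ccco1)C(=O)c1ccc(Cn2oc3ccccc3c2=O)cc1` keeps the shared core and differs from compound 2 only in that (a group of 10 heavy atoms (7 carbon, 1 nitrogen, 2 oxygen; one five-membered aromatic ring with 2 hetero atoms, one six-membered aromatic ring of carbon only) in place of a group of 10 heavy atoms (7 carbon, 1 nitrogen, 1 oxygen, 1 sulfur; one five-membered aromatic ring with 2 hetero atoms, one six-membered aromatic ring of carbon only), on a saturated chain carbon bound to an aromatic carbon). For the measured compounds named here, no measured step exchanges a single atom inside this five-membered aromatic ring, so the earlier step does not speak to the direction or size of this change. With nothing to lean on, a change of about the scatter is expected, and compound 3 is estimated near 50000 nM in this assay, between 15000 nM and 170000 nM, meaning an expected step of a 1.4-fold lower number from compound 2 to compound 3 (0.13 log units; within the scatter).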

Compound 3, half-maximal inhibitory concentration: 6690 nM
Compound 3: middle estimate off by 7.5-fold (0.87 log units), on the high side; the measured number lies below the stated range.
By their numbers in this assay, from the lowest: compounds 1 and 3 (each within the scatter of the next); then compound 2.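

In this assay, this position responds strongly to one atom: oxygen in place of sulfur in the five-membered aromatic ring gives a 10-fold lower number from compound 2 to compound 3 (1.01 log units; beyond the scatter), although the counts of heavy atoms, hydrogen-bond donors and hydrogen-bond acceptors stay the same. The earlier step exchanged the whole group at once, whereas a 1.9-fold higher number from compound 1 to compound 3 (0.29 log units; within the scatter) lies within the scatter, so this assay does not separate the groups carried by these two compounds. No supporting evidence explains why this single atom matters so much.

Still open, going by these compounds, is whether a nitrogen carrying a methyl group, in place of that ring oxygen, would give a number closer to that of compound 2 or compound 3. Also open, on these data alone, is whether the same exchange would give a step of similar size with a carboxylic acid added to the shared core.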